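The compounds below may be only part of what the source reports. "The series", "measured", "known", "first", "only" and "open" are said of these compounds alone.

Measured so far:
compound 1 `Cn1c(=O)c(S(=O)(=O)c2ccccc2)cc2cnc(Nc3cnc4[nH]ccc4c3)nc21`: 5000 nM
compound 2 `Cn1c(=O)c(S(=O)(=O)c2ccc(F)cc2F)cc2cnc(Nc3ccc4cccc(O)c4n3)nc21`: 5000 nM

In a functional assay on K562 cells (Homo sapiens) for inhibition, read by trypan blue exclusion, with a stated time of 72 h (on this read-out higher numbers stand for weaker inhibition and lower numbers for stronger inhibition), compound 1 gives 5000 nM and compound 2 gives 5000 nM; the two values sit level with each other, within the scatter. Compound 3 `Cn1c(=O)c(S(=O)(=O)c2ccc(F)cc2F)cc2cnc(NCc3ccc4[nH]ccc4c3)nc21` differs from compound 2 in one place: (1H-indol-5-yl)methyl in place of 8-hydroxyquinolin-2-yl on a nitrogen on an aromatic ring. Going by the values given here, no step between measured compounds is known for this change, and nothing in the two values points in either direction. The step from compound 2 to compound 3 is expected to be no change at the digits printed from compound 2 to compound 3 (within the scatter), none beyond the scatter. Compound 3 is estimated at 5000 nM, range 2000 nM to 15000 nM in this assay.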

Compound 3, half-maximal inhibitory concentration: 75000 nM
The estimate for compound 3 lay 15-fold (1.18 log units) below the measured number; measured number outside the range, above it.
By their numbers in this assay, from the lowest: compounds 1 and 2 (each within the scatter of the next); then compound 3.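

In this assay the group on this nitrogen proves not to be interchangeable: (1H-indol-5-yl)methyl in place of 8-hydroxyquinolin-2-yl gives a large step, a 15-fold higher number from compound 2 to compound 3 (1.18 log units; beyond the scatter), the first single-place change read in the series. The level values of compound 1 and compound 2 gave no sign of this sensitivity. Nothing at hand accounts for the step.

Which part of the change carries the step stays open, the ring system or the methylene link. A directly attached 1H-indol-5-yl group or a plain benzyl group on the same nitrogen would separate the two.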